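Aryl replacement on the shared core: thiadiazole for pyridine

The source may report more compounds than this note shows. Statements on the series, on what has been measured and on what is new or still open speak of the compounds shown alone.

Compound 2 `CCC(C)(C)Cc1c[nH]c(CCc2ccc(-c3ccncc3)cc2)n1` gives 15 nM in a functional assay on HEK293 cells for agonist activity at Bombesin receptor subtype-3 (Mus musculus), read by luminescence and calcium flux, with a stated time of 10 min; on this read-out higher numbers stand for an effect only at larger amounts of compound and lower numbers for an effect already at smaller amounts. Among the three compounds measured it holds the second highest number; compound 3 `c1ccc(-c2ccc(CCc3nc(CC4CCCC4)c[nH]3)cc2)nc1` gives 22 nM, which lies within the scatter of compound 2, while compound 1 `CCC(C)(C)Cc1c[nH]c(CCc2ccc(-c3cccc(N)n3)cc2)n1` gives 3.9 nM, so the step of a 3.8-fold higher number from compound 1 to compound 2 (0.59 log units; beyond the scatter) is beyond the scatter. For the measured compounds named here, that one step is the only measured change at the same place, and it is modest. Going by the values given here, compound 3 differs from compound 2 in two places, so its value adds no direct step.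

Compound 4 `CCC(C)(C)Cc1c[nH]c(CCc2ccc(-c3csnn3)cc2)n1` carries 1,2,3-thiadiazol-4-yl in place of pyridin-4-yl on an aromatic carbon. Among the compounds with values here, the one relevant step shows that exchanging the aryl group at this position on the shared core moves the number modestly, and the single measured compound with a six-membered ring bearing one nitrogen at this place gives a number within the scatter of compound 3. For compound 4 a modest step in the direction of a higher number is expected, a 2.3-fold higher number from compound 2 to compound 4 (0.37 log units; beyond the scatter), and compound 4 is estimated at 35 nM with a range from 10 nM to 120 nM.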

Compound 4, half-maximal effective concentration: 11 nM
Compound 4: middle estimate off by 3.2-fold (0.50 log units), on the high side; the measured number falls inside the stated range.
By their numbers in this assay, from the lowest: compound 1; then compounds 4, 2 and 3 (each within the scatter of the next).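

Exchanging the six-membered pyridin-4-yl for the five-membered 1,2,3-thiadiazol-4-yl, on an aromatic carbon para to a large group, gives no readable difference: a 1.4-fold lower number from compound 2 to compound 4 (0.13 log units; within the scatter). This place therefore accepts either ring in this pair, despite their different ring sizes and hetero atom counts, while 6-aminopyridin-2-yl stays apart from the thiadiazole as well as from pyridin-4-yl, with a 2.8-fold higher number from compound 1 to compound 4 (0.45 log units; beyond the scatter). No measurement of any property of these groups bears on this result.

The compounds shown do not separate the contribution of the amine in compound 1 from that of its pyridine ring and attachment point. Also open, from the compounds shown here alone, is whether an amine on the 1,2,3-thiadiazole, or a hydroxyl or methylamino group in place of that amine, would give a number nearer that of compound 1.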